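Series notes: from compound 3 to compound 4

This account rests on a few compounds, and the source may have more. Where it says the series, first, only, none or still open, it means among the compounds named here.

Measured so far:
- compound 1 `C=CCONC(=O)Cn1ccc(C(=O)N[C@@H](C)C(=O)N[C@@H](CC(C)C)C(=O)O)c1`: > 128000 nM
- compound 2 `CC(C)C[C@H](NC(=O)CNC(=O)c1ccn(CC(=O)NOCc2ccccc2)c1)C(=O)O`: > 128000 nM
- compound 3 `CC(C)[C@H](NC(=O)[C@H](C)NC(=O)c1ccn(CC(=O)NOCc2ccccc2)c1)C(=O)O`: > 128000 nM

In a functional assay on RAW264.7 cells (Mus musculus) for inhibition, read by microscopy and resazurin assay, with a stated time of 72 h (on this read-out lower numbers stand for stronger inhibition and higher numbers for weaker inhibition), compound 3 gives only a limit, > 128000 nM. Compound 1 likewise gives a limit in this assay. Compound 2 gives a limit too. No numerical value exists in the set; every value shown sits at the limit of > 128000 nM in this assay, at which 3 of the 3 values shown sit. Compound 4 `CC(C)C[C@H](NC(=O)[C@H](C)NC(=O)c1ccn(CC(=O)NOCc2ccccc2)c1)C(=O)O` differs from compound 3 by isobutyl in place of isopropyl on a saturated chain carbon bound to an amide-type nitrogen and a carbonyl carbon. Among the measured compounds shown here, no step between measured compounds is available, so no direction can be read from the set. The change is expected to give no step beyond the scatter, a step that the limit leaves unreadable from compound 3 to compound 4. Compound 4 is estimated at 200000 nM, from 128000 nM to 1000000 nM, and is expected to return only a limit again.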

Compound 4, half-maximal inhibitory concentration: > 128000 nM
Compound 4 was reported as a limit (the forecaster's own chance of this, stated with the estimate: 90%); the middle value is on the limit's open side.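

In this assay, among the compounds shown here, compound 4 gives only a limit, > 128000 nM, so no step linking it to compound 1, compound 2 or compound 3 can be read. The compounds shown leave open whether any of these changes alters inhibition, because all of them sit at one limit: the limit of > 128000 nM in this assay, at which 4 of the 4 values shown sit.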